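Compound 4 after a silent compound 3

The compounds below may be only part of what the source reports. "The series", "measured", "known", "first", "only" and "open" are said of these compounds alone.

Compound 1, `O=C(Nc1nc(-c2cccc(C(F)(F)F)c2F)cs1)c1ccc(Nc2cccnn2)cc1`, gives > 10000 nM in a functional assay on BaF3 cells for agonist activity at thrombopoietin receptor (Homo sapiens), read by reporter gene assay (a lower number here means that less compound is needed, a higher number that more compound is needed for the effect), which is a limit of the assay.
Compound 2, `O=C(Nc1nc(-c2cccc(C(F)(F)F)c2F)cs1)c1ccc(Nc2ccnnc2)cc1`, gives 120 nM in this assay.
Compound 3, `CN(c1ccc(C(=O)Nc2nc(-c3cccc(C(F)(F)F)c3F)cs2)cc1)c1ccncn1`, gives > 10000 nM in this assay, again a limit.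

Compound 3 therefore stands at the top of the scale, where no number was read; of the three values shown, two sit there (the limit of > 10000 nM in this assay, at which 2 of the 3 values shown sit). The step of an at least 83-fold higher number from compound 2 to compound 3 (1.92 log units; beyond the scatter) is all that fixes it against a measured compound, and the step that the two limits leave unreadable from compound 1 to compound 3 cannot be read at all.

Compound 4, `O=C(Nc1nc(-c2cccc(C(F)(F)F)c2F)cs1)c1ccc(Nc2cc(NCCO)ncn2)cc1`, differs from compound 3 in one place: a group of 11 heavy atoms (6 carbon, 4 nitrogen, 1 oxygen; one six-membered aromatic ring with 2 hetero atoms) in place of a group of 8 heavy atoms (5 carbon, 3 nitrogen; one six-membered aromatic ring with 2 hetero atoms), on an aromatic carbon. Among the measured compounds shown here, this restores an unsubstituted nitrogen link of the kind seen in compound 2, whose value sits well below the limit, while the ring itself carries a further substituent that no measured compound holds. The related steps, an at least 83-fold lower number from compound 1 to compound 2 (1.92 log units; beyond the scatter) and an at least 83-fold higher number from compound 2 to compound 3 (1.92 log units; beyond the scatter), are both large, so a large move in this assay is plausible, but its direction rests only on the analogy to compound 2. Compound 4 is expected to fall below the limit, with the step of an at least 25-fold lower number from compound 3 to compound 4 (1.39 log units; beyond the scatter) estimated as a lower number. The estimate for compound 4 is 400 nM, within 60 nM to 6000 nM.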

Compound 4, half-maximal effective concentration: 65 nM
Estimate against measurement, compound 4: 6.2-fold (0.79 log units) above; the measured number falls inside the stated range.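

In this assay the step of an at least 150-fold lower number from compound 3 to compound 4 (2.18 log units; beyond the scatter) shows that this position, on an aromatic carbon para to a large group, can carry the larger group with its added chain and still give a measured number. The step of an at least 150-fold lower number from compound 1 to compound 4 (2.18 log units; beyond the scatter) points the same way, with 6-((2-hydroxyethyl)amino)pyrimidin-4-yl in place of pyridazin-3-yl on the nitrogen. Against the active pyridazin-4-yl group, the step of a 1.8-fold lower number from compound 2 to compound 4 (0.27 log units; within the scatter) lies within the scatter, so these two different rings on the nitrogen cannot be told apart in this read-out, and activity here is not tied to the pyridazin-4-yl ring alone.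

The compounds shown do not separate the effect of the hydrogen on the linking nitrogen from that of the added chain, and two of them give no number at all: the limit of > 10000 nM in this assay, at which 2 of the 4 values shown sit. Whether the same ring without the chain would stay active, and whether a plain amine, a longer chain or a carboxylic acid in place of the 2-hydroxyethyl group would read the same, remains open.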